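Sulfonyl aryl change: compound 2 to compound 3

The source may hold more compounds than are shown below. What is called first, only, known or untested is meant among the compounds shown, and "the series" means these compounds.

In an ADME assay on HEK-293T cells (Homo sapiens) for inhibition, read by CCK-8 assay, with a stated time of 48 h, tested at 20 uM (a lower number here means less inhibition of growth, a higher number more inhibition of growth at the concentration tested), compound 2 (`N#C/C(=C\c1ccccc1OS(=O)(=O)c1ccccc1[N+](=O)[O-])C(=O)Nc1nnc(Cc2ccccc2)s1`) gives 10% and compound 1 (`Cc1ccc(S(=O)(=O)Oc2ccccc2/C=C(\C#N)C(=O)Nc2nnc(Cc3ccccc3)s2)cc1`) gives 15%, two values within the scatter of each other. Compound 3 (`N#C/C(=C\c1ccccc1OS(=O)(=O)c1ccc(F)cc1)C(=O)Nc1nnc(Cc2ccccc2)s1`) carries 4-fluorophenyl in place of 2-nitrophenyl on a sulfonyl sulfur. Among the compounds with values here, the only measured step at this place is a number 5 percentage points lower from compound 1 to compound 2 (within the scatter), so nothing beyond the scatter is expected in this assay. The expected change is a number 2 percentage points higher from compound 2 to compound 3 (within the scatter). For compound 3 the estimated value is 12%, with an expected range of 2% to 25%.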

Compound 3, percent growth inhibition at one concentration: 6%
The estimate for compound 3 lay 6 percentage points above the measured number; the range from low to high includes it.
By their numbers in this assay, from the lowest: compounds 3, 2 and 1 (each within the scatter of the next).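

In this assay the 4-fluorophenyl group gives a number 4 percentage points lower from compound 2 to compound 3 (within the scatter) and the swap of fluoro for methyl on an aromatic carbon gives a number 9 percentage points lower from compound 1 to compound 3 (within the scatter) as its step. All three aryl groups on the sulfonyl sulfur now lie within the scatter of one another, so neither the 2-nitrophenyl nor the 4-fluorophenyl group separates from the 4-methylphenyl group at the concentration tested. No supporting data bear on this result.

Still open, going by these compounds, is whether an aryl ring carrying an amine or a carboxylic acid would leave the scatter. The same question applies to a plain methyl on the sulfonyl sulfur.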